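Aryl vinyl sulfone series: expectation for compound 4

This account rests on a few compounds, and the source may have more. Where it says the series, first, only, none or still open, it means among the compounds named here.

Measured so far in a functional assay on DU-145 cells (Homo sapiens) for inhibition, read by trypan blue exclusion, with a stated time of 96 h; a higher number here means a weaker inhibitor of growth, a lower number a stronger inhibitor of growth:
compound 1 `Cc1ccc(S(=O)(=O)/C(=C/c2ccc(C)s2)C(=O)c2ccc(Cl)cc2)cc1` gives 50000 nM
compound 2 `O=C(/C(=C\c1ccccc1F)S(=O)(=O)c1ccc(Br)cc1)c1ccc(Cl)cc1` gives 25000 nM
compound 3 `Cc1ccc(S(=O)(=O)/C(=C/c2ccccc2F)C(=O)c2ccc(Cl)cc2)cc1` gives 2500 nM

Compound 3 stands lowest of the three; the steps to compound 2 and compound 1 are both beyond the scatter. Compound 4 `CC(=O)Oc1ccc(/C=C(\C(=O)c2ccc(Cl)cc2)S(=O)(=O)c2ccc(C)cc2)cc1` is not yet measured. Its change from compound 3: 4-acetoxyphenyl in place of 2-fluorophenyl on a double-bonded chain carbon bound to a double-bonded chain carbon. Going by the values given here, the only measured step at that place is a 20-fold lower number from compound 1 to compound 3 (1.30 log units; beyond the scatter), a large step, but it does not involve 4-acetoxyphenyl, so it gives direction only loosely. The step of a 10-fold lower number from compound 2 to compound 3 (1.00 log units; beyond the scatter) lies elsewhere and does not bear on this change. Among the compounds with values here, with no direct precedent, a step of modest size is expected, more likely upward than downward, as a 2.4-fold higher number from compound 3 to compound 4 (0.38 log units; beyond the scatter). Compound 4 is estimated at 6000 nM, with a range from 1500 nM to 25000 nM.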

Compound 4, concentration for 50% growth inhibition: 25000 nM
For compound 4 the middle estimate is 4.2-fold (0.62 log units) below the measured one; measured number inside the range.
By their numbers in this assay, from the lowest: compound 3; then compounds 2, 4 and 1 (each within the scatter of the next).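

In this assay the 4-acetoxyphenyl group at this place shows a 10-fold higher number from compound 3 to compound 4 (1.00 log units; beyond the scatter) and so joins 5-methylthiophen-2-yl in falling short of 2-fluorophenyl. These two groups are not told apart, with a 2.0-fold lower number from compound 1 to compound 4 (0.30 log units; within the scatter) as the step between them, so the edge of compound 3 now holds against two different groups. Nothing measured on these compounds explains the step.

Still open, on these data alone, is whether a phenyl group carrying an amine or a carboxylic acid at this place would come near compound 3 in this assay. Also open, as far as these compounds go, is whether the gain from methyl in place of bromo carries over to other groups at this place.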